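This account rests on a few compounds, and the source may have more. Where it says the series, first, only, none or still open, it means among the compounds named here.

Compounds measured so far:
- compound 1, `O=S(=O)(/C=C/c1ccc(O)c(O)c1)NCc1ccccc1`, in a functional assay on BV-2 cells (Mus musculus) for inhibition, read by Griess assay, with stated times of 3 h and 24 h (on this read-out lower numbers stand for stronger inhibition and higher numbers for weaker inhibition), compound 1 gives 21500 nM.
- compound 2, `O=S(=O)(/C=C/c1ccc(O)c(O)c1)NCc1ccc(C(F)(F)F)cc1`, in this assay compound 2 gives 12600 nM.

Compound 2 stands at the lowest of the two numbers, but its gap to compound 1 is small. Among the compounds with values here, the only step at hand, a 1.7-fold lower number from compound 1 to compound 2 (0.23 log units; within the scatter), stays within the scatter. The next compound, compound 3 `Cc1ccc(CNS(=O)(=O)/C=C/c2ccc(O)c(O)c2)cc1`, changes the same spot again: methyl in place of trifluoromethyl on an aromatic carbon. That step touches only the group whose earlier swap left the number almost unchanged, so no movement beyond the scatter is expected. For compound 3 the expected value in this assay is 15000 nM, within 6000 nM to 40000 nM, an expected step of a 1.2-fold higher number from compound 2 to compound 3 (0.08 log units; within the scatter).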

Compound 3, half-maximal inhibitory concentration: 43900 nM
For compound 3 the middle estimate is 2.9-fold (0.47 log units) below the measured one; measured number outside the range, above it.
By their numbers in this assay, from the lowest: compounds 2 and 1 (each within the scatter of the next); then compound 3.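

In this assay this position turns out to matter: methyl brings a 3.5-fold higher number from compound 2 to compound 3 (0.54 log units; beyond the scatter) and a 2.0-fold higher number from compound 1 to compound 3 (0.31 log units; beyond the scatter) while hydrogen and trifluoromethyl stay within the scatter of each other. The numbers therefore do not follow the heavy-atom count of the group, as methyl falls out of line with both hydrogen and the larger trifluoromethyl. Nothing at hand explains this shift. On these data alone, whether the weaker inhibition is particular to methyl remains open, and so does what a methoxy group, a chlorine atom or an amine would give at this place.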